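Bromoacrylamide series: the benzyl-to-phenyl change in prospect

This account rests on a few compounds, and the source may have more. Where it says the series, first, only, none or still open, it means among the compounds named here.

Measured in a functional assay on HeLa cells (Homo sapiens) for inhibition, read by cell counting, with a stated time of 4 days; on this read-out lower numbers stand for stronger inhibition and higher numbers for weaker inhibition:
Compound 1, `C=C(Br)C(=O)Nc1cccc(-c2cn3nc(Cc4ccc(Cl)cc4)sc3n2)c1`: 2700 nM
Compound 2, `Nc1cccc(-c2cn3nc(Cc4ccc(Cl)cc4)sc3n2)c1`: 25000 nM
Compound 3, `C=C(Br)C(=O)Nc1cccc(-c2cn3c(-c4ccccc4)csc3n2)c1`: 3400 nM

Compound 1 has the lowest of the three numbers. Compound 3, which keeps the amide but differs in the core, lies within the scatter of it, so the two cannot be ordered. Compound 2 stands furthest away: a 9.3-fold higher number from compound 1 to compound 2 (0.97 log units; beyond the scatter), a step beyond the scatter.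

The unmeasured compound 4, `C=C(Br)C(=O)Nc1cccc(-c2cn3nc(-c4ccc(Cl)cc4)sc3n2)c1`, differs from compound 1 in one place: 4-chlorophenyl in place of 4-chlorobenzyl on an aromatic carbon. Within the data shown here, no measured step bears directly on this change. Among the measured compounds shown here, the one step known, from compound 1 to compound 2, concerns the amide end and is unrelated. The pair of compound 1 and compound 3 shows only that a phenyl on the core, in another arrangement, gives a number within the scatter. With nothing pointing either way, no step beyond the scatter is expected in this assay. Compound 4 is estimated at 3000 nM, with a range from 1000 nM to 9000 nM. The estimated step is a 1.1-fold higher number from compound 1 to compound 4 (0.05 log units; within the scatter).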

Compound 4, half-maximal inhibitory concentration: 3000 nM
Estimate against measurement, compound 4: no gap at the digits printed, within the range that was stated.
By their numbers in this assay, from the lowest: compounds 1, 4 and 3 (each within the scatter of the next); then compound 2.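

Notes on the position: in this assay, 4-chlorophenyl in place of 4-chlorobenzyl on the aromatic carbon next to the ring sulfur gives a 1.1-fold higher number from compound 1 to compound 4 (0.05 log units; within the scatter), so this read-out does not separate the two groups at this position. Among these compounds, this is the first one-place step at this end of the molecule, and the amide end still holds the only step beyond the scatter. No measured data offer an explanation for this result.

Open: whether a carboxylic acid, an amine or a longer chain such as 2-(4-chlorophenyl)ethyl at this carbon would also stay within the scatter of compound 1. Also open, on these data alone, is whether removing the (1-bromoethenyl)carbonyl from compound 4 would give a step like a 9.3-fold higher number from compound 1 to compound 2 (0.97 log units; beyond the scatter).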